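A few compounds are considered here, and "the series" means these few. Any claim that something is new, unique, unknown or untested is made for them only; others in the source may bear on it.

Three compounds have been measured in a physicochemical assay, read by spectrophotometry, with a stated time of 6 min; a lower number here means a stronger inhibitor, a higher number a weaker inhibitor:

compound 1 `O=C(CCc1nc2ccccc2c(=O)[nH]1)N/N=C/c1ccc(O)c(O)c1`, 40000000 nM;
compound 2 `COc1cc(/C=N/NC(=O)CCCc2nc3ccccc3c(=O)[nH]2)cc(OC)c1O`, 135000000 nM;
compound 3 `COc1cc(/C=N/NC(=O)CCc2nc3ccccc3c(=O)[nH]2)cc(O)c1O`, 40000000 nM.

Compound 1 stands level with compound 3, the two sharing the lowest number of the three; compound 2 gives a higher number than either, but it differs from compound 1 in more than one place, so the pair shows only that gap. Going by the values given here, the single one-place step recorded, no change at the digits printed from compound 1 to compound 3 (within the scatter), was flat.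

Compound 4 `O=C(CCc1nc2ccccc2c(=O)[nH]1)N/N=C/c1ccc(O)cc1` differs from compound 1 by hydrogen in place of hydroxy on an aromatic carbon. Among the compounds with values here, no measured step involves a hydroxy leaving, so the expectation rests on thin ground: the only one-place step, no change at the digits printed from compound 1 to compound 3 (within the scatter), concerns a methoxy entering and lay within the scatter, and the gap between compound 1 and compound 2 cannot be read as a single change. Compound 4 is therefore expected to sit somewhat weaker than compound 1, an expected step of a 2.5-fold higher number from compound 1 to compound 4 (0.40 log units; beyond the scatter), held with wide uncertainty because no change at the digits printed from compound 1 to compound 3 (within the scatter) offers no direct guide. The estimate for compound 4 in this assay is 100000000 nM, between 40000000 nM and 400000000 nM.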

Compound 4, half-maximal inhibitory concentration: 105000000 nM
Estimate against measurement, compound 4: 1.1-fold (0.02 log units) below; the range from low to high includes it.
By their numbers in this assay, from the lowest: compounds 1 and 3 (each within the scatter of the next); then compounds 4 and 2 (each within the scatter of the next).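

In this assay the change from 3,4-dihydroxyphenyl to 4-hydroxyphenyl gives a 2.6-fold higher number from compound 1 to compound 4 (0.42 log units; beyond the scatter) and so makes a modest but real difference: with the hydroxy at this place on the aromatic carbon gone, compound 4 is a weaker inhibitor than compound 1. The earlier one-place step on this ring, no change at the digits printed from compound 1 to compound 3 (within the scatter), had stayed within the scatter, so this is the first single change on the ring shown to move the number. Nothing at hand says why removing this hydroxy has this effect.

The compounds shown leave open whether a hydroxy is specifically needed at this place, or whether an amine or a fluorine there would serve as well. They also leave open what removing the remaining hydroxy of compound 4 would do.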